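A few compounds are considered here, and "the series" means these few. Any claim that something is new, unique, unknown or untested is made for them only; others in the source may bear on it.

Results so far in an ADME assay on S9 fraction (Rattus norvegicus) for metabolic stability, with a stated time of 60 min (on this read-out higher numbers stand for a more stable compound and lower numbers for a less stable compound), for the two measured compounds:

- Compound 1 `COCCN1C(=O)CNc2ncc(-c3ccc(C(C)(C)O)nc3)nc21` gives 89% here
- Compound 2 `CC(C)(O)c1ccc(-c2cnc3c(n2)N(CC2CCCCC2)CC(=O)N3)cn1` gives 16% here

Compound 1 holds the higher of the two numbers, and the gap to compound 2 lies well beyond the usual scatter. The next compound to be tested is compound 3 `CO[C@H]1CC[C@H](N2C(=O)CNc3ncc(-c4ccc(C(C)(C)O)nc4)nc32)CC1`. It keeps the rest of compound 1 and makes one change: 4-methoxycyclohexyl in place of 2-methoxyethyl on an amide-type nitrogen in a ring. In words, this is 4-methoxycyclohexyl in place of 2-methoxyethyl on an amide-type nitrogen in a ring. For the measured compounds named here, no measured pair isolates this change, so the data offer no direct guide to its size. Compound 1 (89%) leaves little room to rise, while compound 2 (16%) shows how far a compound in this small set can sit lower. A fall beyond the scatter therefore seems the likelier outcome, and the expected step is a number 31 percentage points lower from compound 1 to compound 3 (beyond the scatter) in this assay, though with wide uncertainty. Compound 3 is estimated at 58% with an expected range of 28% to 85% for now.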

Compound 3, percent of the compound remaining: 81%
Compound 3: middle estimate off by 23 percentage points, on the low side; the range from low to high includes it.
By their numbers in this assay, from the lowest: compound 2; then compounds 3 and 1 (each within the scatter of the next).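

In this assay, replacing 2-methoxyethyl with 4-methoxycyclohexyl on this ring nitrogen changes the group from a small open chain to one with a six-membered carbon ring and two defined stereocentres, yet the step is a number 8 percentage points lower from compound 1 to compound 3 (within the scatter), so the two groups cannot be told apart on this read-out. A six-membered carbon ring in the group on this nitrogen therefore does not by itself go with a low number: compound 3 gives 81%, while compound 2, whose group also holds such a ring but no methoxy, gives 16%. Nothing available explains why compound 3 stays in the same range as compound 1 or why compound 2 sits so much lower.

The role of the methoxy remains unsettled, as compound 2 and compound 3 also differ in how the ring is joined to the nitrogen, and a 4-hydroxycyclohexyl group or a plain cyclohexyl group would test it more directly. On these data alone, whether the other stereochemical arrangement of 4-methoxycyclohexyl, or a ring holding an amine such as piperidine, would give a similar number also stays open.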